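Acetylation of the ring hydroxyl in a lactone series

This account rests on a few compounds, and the source may have more. Where it says the series, first, only, none or still open, it means among the compounds named here.

Compound 1, `CC(=O)O[C@@H]1OC(=O)[C@](OC(C)=O)(C(C)=O)[C@@H]1C`: in a functional assay on B16 cells (Mus musculus) for cytotoxicity, read by MTT assay (on this read-out higher numbers stand for weaker inhibition and lower numbers for stronger inhibition), compound 1 gives > 50000 nM, which is a limit of the assay.
Compound 2, `CC(=O)O[C@@H]1OC(=O)[C@@](Cc2ccccc2)(C(C)=O)[C@@H]1C`: in this assay compound 2 gives 45000 nM.
Compound 3, `CC(=O)O[C@@H]1OC(=O)[C@@](O)(C(C)=O)[C@@H]1C`: in this assay compound 3 gives > 50000 nM, which is a limit of the assay.

Compound 3 therefore stands at the assay limit, and no number is known for it; compound 1 also sits at a limit, and only compound 2 returns a number. Among the compounds with values here, the single measured step, an at least 1.1-fold higher number from compound 2 to compound 3 (0.04 log units; that floor lies within the scatter), runs from a number into a limit, so its true size is known only as a floor because of the limit of > 50000 nM in this assay, at which 2 of the 3 values shown sit. Compound 4, `CC(=O)O[C@@H]1OC(=O)[C@@](OC(C)=O)(C(C)=O)[C@@H]1C`, differs from compound 3 by acetyl in place of hydrogen on an oxygen on a saturated carbon. Within the data shown here, no measured step covers this change, and the starting point is itself a limit. The expectation in this assay is no step beyond the scatter, a step that the limit leaves unreadable from compound 3 to compound 4, most probably another limit. Compound 4 is estimated at 60000 nM, within 20000 nM to 200000 nM.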

Compound 4, half-maximal inhibitory concentration: > 50000 nM
Compound 4 ended at the assay's limit (the forecaster's own chance of this, stated with the estimate: 75%); the middle value is on the limit's open side.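

Acetoxy in place of hydroxy on this saturated ring carbon leaves the series at the limit of this assay, and both drawn configurations of the acetoxy compound sit at that limit. Against benzyl, the result is an at least 1.1-fold higher number from compound 2 to compound 4 (0.04 log units; that floor lies within the scatter), so acetoxy is not separated from benzyl at this position. The steps from compound 3 to compound 4 and from compound 1 to compound 4 cannot be read because of this: the limit of > 50000 nM in this assay, at which 3 of the 4 values shown sit.

Going by these compounds, the size of the acetyl change and any effect of configuration stay open. Also open, on these data alone, is whether an amine or a longer chain on this carbon would give a number.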